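The source may hold more compounds than are shown below. What is called first, only, known or untested is meant among the compounds shown, and "the series" means these compounds.

Working notes on the series. Compound 1 `COc1cc(OC)c(C(=O)/C=C/c2ccccc2SC)c(OC)c1` in a functional assay on HaCaT cells (Homo sapiens), read by fluorescence and BrdU incorporation, with a stated time of 48 h, tested at 10 uM (a higher number here means a weaker effect of the compound at the concentration tested, a lower number a stronger effect), gives 24%. Compound 2 `COc1cc(OC)c(C(=O)/C=C/c2ccc(F)cc2)c(OC)c1` gives 20% and compound 3 `COc1cc(OC)c(C(=O)/C=C/c2ccc(Br)cc2)c(OC)c1` gives 24%; with a number 4 percentage points lower from compound 1 to compound 2 (within the scatter), no change at the digits printed from compound 1 to compound 3 (within the scatter) and a number 4 percentage points higher from compound 2 to compound 3 (within the scatter), compound 1 is level with compound 3 and the pair holds the highest of the three numbers, all within scatter of one another. Compound 4 `COc1cc(O)c(C(=O)/C=C/c2ccccc2SC)c(OC)c1` differs from compound 1 by hydrogen in place of methyl on an oxygen on an aromatic ring. Going by the values given here, every measured step exchanges the group on the double-bonded chain carbon; none touches an oxygen on the aromatic ring of the shared core, so no measured step bears on this change. The expected step is therefore no change at the digits printed from compound 1 to compound 4 (within the scatter), none beyond the scatter. Compound 4 is estimated at 24%, with a range from 8% to 42%.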

Compound 4, a percentage reported as activity, at one concentration (the size of the read-out at that concentration, not a potency): 51%
The estimate for compound 4 lay 27 percentage points below the measured number; the measured number lies above the stated range.
By their numbers in this assay, from the lowest: compounds 2, 1 and 3 (each within the scatter of the next); then compound 4.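

On an oxygen on an aromatic ring the series is sensitive to change: in this assay hydrogen in place of methyl gives a number 27 percentage points higher from compound 1 to compound 4 (beyond the scatter) and so a weaker effect at the concentration tested. The exchanges on the double-bonded chain carbon among compound 1, compound 2 and compound 3 all stay within the scatter, so this is the first step shown to lie beyond it. The data shown offer no evidence that explains this step. From the compounds shown here alone, whether ethoxy or an amino group in place of methoxy would read like compound 1 or like compound 4 stays open. So does whether methoxy to hydroxy has the same size with the 4-fluorophenyl of compound 2 or the 4-bromophenyl of compound 3.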